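Does a longer chain change inhibition?

The source may report more compounds than this note shows. Statements on the series, on what has been measured and on what is new or still open speak of the compounds shown alone.

In a functional assay on MOLT-3 cells (Homo sapiens) (on this read-out lower numbers stand for stronger inhibition and higher numbers for weaker inhibition), compound 1 (`CCCCCSC[C@H](NC(C)=O)C(=O)CCl`) gives 5400 nM as its measured value, while compound 2 (`CCCCCCCCCSC[C@H](NC(C)=O)C(=O)CCl`) gives 6700 nM on the same scale. These two numbers lie within the usual scatter of repeated measurements, so compound 2 cannot be told apart from compound 1. Compound 3 (`CCCCCCCCCCCCCCCSC[C@H](NC(C)=O)C(=O)CCl`) has not yet been measured. It keeps the shared core, and its difference from compound 2 is hexyl in place of hydrogen on a saturated chain carbon, nine bonds along the chain from a sulfur on a saturated chain carbon, nine bonds along the chain from a sulfur. For the measured compounds named here, only one measured step bears on this change, and it too extends the chain: butyl in place of hydrogen gave a 1.2-fold higher number from compound 1 to compound 2 (0.09 log units; within the scatter) in this assay without moving the result beyond the scatter. A single step is thin evidence, and the new extension is longer than the butyl one, so the range must stay wide. No shift beyond the scatter is expected, and the estimated step is a 1.1-fold lower number from compound 2 to compound 3 (0.05 log units; within the scatter) in either direction within that range. The expected value for compound 3 is 6000 nM (estimated range 2000 nM to 20000 nM).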

Compound 3, half-maximal inhibitory concentration: 8600 nM
Beside the measured number, compound 3's estimate is 1.4-fold (0.16 log units) below it, and the stated range covers the measured number.
By their numbers in this assay, from the lowest: compounds 1, 2 and 3 (each within the scatter of the next).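

In this assay, hexyl in place of hydrogen on a saturated chain carbon, nine bonds along the chain from a sulfur, gives a 1.3-fold higher number from compound 2 to compound 3 (0.11 log units; within the scatter). This second extension adds more carbon than the butyl extension did, yet it also stays within the usual scatter, so at this position neither added stretch of chain separates a compound from its shorter neighbour. The earlier step, a 1.2-fold higher number from compound 1 to compound 2 (0.09 log units; within the scatter), points the same way numerically, but both steps are within the scatter, so they do not establish a real rise in the number as the chain grows. Nothing else is available to explain the result.

The compounds shown leave open whether a much shorter chain, such as methyl or ethyl, or a still longer chain would give a number that clearly differs from these. They also leave open whether a group of another kind in place of the plain chain end, such as an amine, a carboxylic acid or a phenyl ring, would move the result beyond the scatter in this assay.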